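A Side-Chain Swap Carried from One Core to Another

The compounds below may be only part of what the source reports. "The series", "measured", "known", "first", "only" and "open" are said of these compounds alone.

Measured compounds:
compound 1 `COC(=O)C[C@H](NC(=O)OC(C)(C)C)C(=O)N(Cc1ccccc1)C1(C(=O)NCc2ccccc2)CCN(Cc2ccccc2)CC1` gives 18000 nM
compound 2 `CC[C@H](C)[C@H](NC(=O)OC(C)(C)C)C(=O)N(Cc1ccccc1)C1(C(=O)NCc2ccccc2)CCN(Cc2ccccc2)CC1` gives 4400 nM
compound 3 `CC[C@H](C)[C@H](NC(=O)OCc1ccccc1)C(=O)N(C1CC1)C1(C(=O)NCc2ccccc2)CCN(Cc2ccccc2)CC1` gives 11000 nM

These values come from a functional assay on L1210 cells (Mus musculus) for inhibition, with a stated time of 48 h; a higher number here means a weaker inhibitor, a lower number a stronger inhibitor. Compound 2 and compound 1 share a core and differ in one place: (methoxycarbonyl)methyl in place of sec-butyl on a saturated chain carbon bound to an amide-type nitrogen and a carbonyl carbon. That change gave a 4.1-fold higher number from compound 2 to compound 1 (0.61 log units; beyond the scatter). Compound 3 carries a different core, and how the core of compound 3 differs from that of compound 2 is not broken down here. Compound 4 `COC(=O)C[C@H](NC(=O)OCc1ccccc1)C(=O)N(C1CC1)C1(C(=O)NCc2ccccc2)CCN(Cc2ccccc2)CC1` is not yet measured and differs from compound 3 by the same change: (methoxycarbonyl)methyl in place of sec-butyl on a saturated chain carbon bound to an amide-type nitrogen and a carbonyl carbon. Because a 4.1-fold higher number from compound 2 to compound 1 (0.61 log units; beyond the scatter) weakened inhibition on the other core, a step of similar size is expected here, a 3.6-fold higher number from compound 3 to compound 4 (0.56 log units; beyond the scatter), though a single example leaves the transfer uncertain. Compound 4 is estimated at 40000 nM, likely between 15000 nM and 110000 nM in this assay.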

Compound 4, half-maximal inhibitory concentration: 5300 nM
Compound 4: the middle estimate sits 7.5-fold (0.88 log units) above what was measured; measured number outside the range, below it.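

On the core of compound 3, putting (methoxycarbonyl)methyl in place of sec-butyl gave a 2.1-fold lower number from compound 3 to compound 4 (0.32 log units; beyond the scatter) in this assay, so the step seen on the first core did not carry over, and the two steps run in opposite directions: the same change on two cores in this assay, a 4.1-fold higher number (0.61 log units; beyond the scatter) from compound 2 to compound 1 and a 2.1-fold lower number (0.32 log units; beyond the scatter) from compound 3 to compound 4, 8.5-fold (0.93 log units) apart, beyond the scatter of two such steps. In this series, then, the result of this change depends on the core that carries it, and a step read on one core is a poor guide to the other. These two pairs do not show which difference between the cores is responsible, and they give no rule for any further core.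

Still open, as far as these compounds go, is how a carboxylic acid or a longer chain at this place would behave on each core. A core differing from that of compound 2 in one place only could show which part of it reverses the step.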